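The compounds below may be only part of what the source reports. "The series", "measured", "known", "first", "only" and "open" are said of these compounds alone.

Of the compounds shown here, two have been measured so far in a functional assay on the whole organism for inhibition, with Rattus norvegicus as the target; a lower number here means that less compound is needed, a higher number that more compound is needed for the effect. Compound 1 (`CS(=O)(=O)c1ccc2c(c1)c(C1CCN(CCN3CCNC3=O)CC1)cn2-c1ccc(F)cc1`) gives 54 umol/kg, whereas compound 2 (`CN1CCN(CCN2CCC(c3cn(-c4ccc(F)cc4)c4ccc(Cl)cc34)CC2)C1=O`) gives 0.021 umol/kg, the lower of the two numbers by a margin well beyond the scatter. These two compounds differ in more than one place, so the gap cannot be tied to any single change. Compound 3 (`O=C1NCCN1CCCCN1CCC(c2cn(-c3ccc(F)cc3)c3ccc(Cl)cc23)CC1`) differs from compound 2 in one place: 2-(2-oxoimidazolidin-1-yl)ethyl in place of 3-methyl-2-oxoimidazolidin-1-yl on a saturated chain carbon, two bonds along the chain from an amine nitrogen in a ring. A 2-(2-oxoimidazolidin-1-yl)ethyl group stands in place of 3-methyl-2-oxoimidazolidin-1-yl, on a saturated chain carbon, two bonds along the chain from an amine nitrogen in a ring. Among the measured compounds shown here, no measured pair isolates this change. Compound 1, at 54 umol/kg, also ends in a 2-oxoimidazolidin-1-yl group, but its core differs, so it offers only a weak hint towards a higher number. In this assay, a moderate rise beyond the scatter is expected, estimated as a 9.5-fold higher number from compound 2 to compound 3 (0.98 log units; beyond the scatter). For compound 3 the expected value is 0.2 umol/kg, with an estimated range from 0.03 umol/kg to 1.5 umol/kg.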

Compound 3, dose for half-maximal effect: > 2.2 umol/kg
Compound 3: a limit, no number; the forecaster's own chance of this, stated with the estimate: 10%; middle value at least 11-fold (1.04 log units) away from the limit.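

In this assay, among the compounds shown here, the single change at this place, on a saturated chain carbon, two bonds along the chain from an amine nitrogen in a ring, gives an at least 100-fold higher number from compound 2 to compound 3 (2.02 log units; beyond the scatter). Unlike the gap between compound 1 and compound 2, this step can be tied to one place, and it shows that the shared core does not keep the low number when this group is exchanged. The number for compound 3 is a limit, so the true size of the step remains unknown: the limit of > 2.2 umol/kg in this assay, at which 1 of the 3 values shown sits.

The change lengthens the chain to 4-(2-oxoimidazolidin-1-yl)butyl and also replaces the ring methyl with the amide hydrogen, so the compounds shown cannot separate these two parts. As far as these compounds go, a 4-(3-methyl-2-oxoimidazolidin-1-yl)butyl group would keep the methyl on the longer chain, and how it would read here remains open.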